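The source may report more compounds than this note shows. Statements on the series, on what has been measured and on what is new or still open speak of the compounds shown alone.

Of the compounds shown here, three have been tested so far in an ADME assay on MDBK cells (Bos taurus) for cytotoxicity, read by MTT assay, with a stated time of 72 h; on this read-out higher numbers stand for lower toxicity in this test and lower numbers for higher toxicity in this test. Compound 1 `FC(F)(F)c1ccc(-c2nn(-c3ccccc3)cc2CNc2ccc(Cl)cc2)cc1` gives a measured 44000 nM. Compound 2 `Brc1ccc(NCc2cn(-c3ccccc3)nc2-c2ccccc2)cc1` reads > 100000 nM, which is a limit. Compound 3 `Cc1ccc(NCc2cn(-c3ccccc3)nc2-c2ccc(Cl)cc2)cc1` reads > 100000 nM, which is also a limit, so it has no exact place on the scale. Its position is the limit of > 100000 nM in this assay, at which 2 of the 3 values shown sit.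

Compound 4 `Cc1ccc(NCc2cn(-c3ccccc3)nc2-c2ccc(C(F)(F)F)cc2)cc1` differs from compound 3 in one place: trifluoromethyl in place of chloro on an aromatic carbon. This puts trifluoromethyl in place of chloro on an aromatic carbon, para to a large group. Among the compounds with values here, compound 1 is the only measured compound carrying the 4-(trifluoromethyl)phenyl group, and it gives 44000 nM, although it also differs from compound 4 elsewhere. A modest step towards lower numbers in this assay is therefore expected, and compound 4 may still reach the limit. The estimated change is an at least 1.4-fold lower number from compound 3 to compound 4 (0.15 log units; that floor lies within the scatter). For compound 4 the expected value is 70000 nM, with an estimated range of 30000 nM to 150000 nM.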

Compound 4, half-maximal cytotoxic concentration: > 100000 nM
Compound 4: a limit, no number; the forecaster's own chance of this, stated with the estimate: 45%; at least 1.4-fold (0.15 log units) between middle value and limit.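

In this assay, trifluoromethyl in place of chloro on this aromatic carbon leaves compound 4 at a limit, as compound 3 is, so the step between them cannot be read. The pair that can be read differs elsewhere, with methyl in place of chloro on an aromatic carbon, and it shows an at least 2.2-fold higher number from compound 1 to compound 4 (0.35 log units; beyond the scatter). The 4-(trifluoromethyl)phenyl group therefore does not on its own go with the lower number of compound 1, which is now the only compound with an exact value, while the others share one position: the limit of > 100000 nM in this assay, at which 3 of the 4 values shown sit.

Where compound 3 and compound 4 truly lie on the scale stays open, so any effect of this change remains unknown. Also open, on these data alone, is how an amine or a carboxylic acid in place of the methyl of compound 4 would read.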